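Adding methoxy to the benzyl group of compound 2

This account rests on a few compounds, and the source may have more. Where it says the series, first, only, none or still open, it means among the compounds named here.

Values in a functional assay on HCT-116 cells (Homo sapiens) for antiproliferative activity, read by sulforhodamine B assay, with a stated time of 72 h (a higher number here means a weaker inhibitor, a lower number a stronger inhibitor), for the compounds measured so far
- compound 1 (`COc1ncc(-c2ccc3ncc(NCc4ccc(C(F)(F)F)cc4)c(OC)c3c2)cc1NS(=O)(=O)c1ccc(F)cc1F`) gives 3220 nM
- compound 2 (`COc1ncc(-c2ccc3ncc(NCc4ccccc4)c(OC)c3c2)cc1NS(=O)(=O)c1ccc(F)cc1F`) gives 16800 nM
- compound 3 (`COc1ncc(-c2ccc3ncc(NCC4CCCCC4)c(OC)c3c2)cc1NS(=O)(=O)c1ccc(F)cc1F`) gives 13600 nM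

Compound 2 gives 16800 nM and sits with compound 3 at the weak end of this small set. Their gap is a 1.2-fold lower number from compound 2 to compound 3 (0.09 log units; within the scatter) and so sets no order between them. The clear gaps are a 5.2-fold higher number from compound 1 to compound 2 (0.72 log units; beyond the scatter) and a 4.2-fold higher number from compound 1 to compound 3 (0.63 log units; beyond the scatter) and both are modest.

Compound 4 (`COc1ccc(CNc2cnc3ccc(-c4cnc(OC)c(NS(=O)(=O)c5ccc(F)cc5F)c4)cc3c2OC)cc1`) keeps all of compound 2 except for one change, methoxy in place of hydrogen on an aromatic carbon, para to a large group (methoxy in place of hydrogen on an aromatic carbon). Going by the values given here, the closest evidence is the first of those clear gaps, where hydrogen takes the place of trifluoromethyl on an aromatic carbon. It shows that a single group on this benzyl ring can shift the number by a modest amount. Methoxy is a different group, however, and no measured compound carries it, so the direction remains uncertain. A small shift towards a lower number seems the likelier outcome, smaller than that gap. The expected step is a 1.5-fold lower number from compound 2 to compound 4 (0.18 log units; within the scatter) and remains only an estimate. The estimated value for compound 4 is 11000 nM with an expected range of 4000 nM to 28000 nM (not yet measured).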

Compound 4, half-maximal inhibitory concentration: 10200 nM
For compound 4 the middle estimate is 1.1-fold (0.03 log units) above the measured one, and the stated range covers the measured number.
By their numbers in this assay, from the lowest: compound 1; then compounds 4, 3 and 2 (each within the scatter of the next).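

In this assay, putting methoxy in place of hydrogen on this carbon of the benzyl ring, para to a large group, gives a 1.6-fold lower number from compound 2 to compound 4 (0.22 log units; within the scatter), so the two compounds cannot be told apart, and the same holds for the swap from cyclohexyl to 4-methoxyphenyl, with a 1.3-fold lower number from compound 3 to compound 4 (0.12 log units; within the scatter). Methoxy and trifluoromethyl at the same place do separate, with a 3.2-fold higher number from compound 1 to compound 4 (0.50 log units; beyond the scatter), which shows that the clear gain seen with compound 1 does not follow from simply having any group on this carbon: compound 4 carries one and still stays within the scatter of compound 2. No measurement here offers an explanation for why trifluoromethyl stands apart from methoxy and hydrogen.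

On these data alone, whether a chlorine atom, a nitrile or a dimethylamino group on this same carbon would fall with compound 1 or with compound 4 remains open. All four compounds also share the rest of their structure, so it is equally unknown whether these gaps would hold on a different core.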